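From Oxadiazole to Thiazole: Expecting the Next Inhibition Value

The source may hold more compounds than are shown below. What is called first, only, known or untested is meant among the compounds shown, and "the series" means these compounds.

Measured so far:
compound 1 `CC1Cc2ccccc2N1S(=O)(=O)c1ccc(-c2cnc(C3CC3)o2)cc1`: 52.4%
compound 2 `O=S(=O)(c1ccc(-c2nnc(C3CC3)o2)cc1)N1CCc2ccccc21`: 63.7%

In a functional assay on A549 cells (Homo sapiens) for inhibition, read by MTT assay, tested at 10 uM (a higher number here means more inhibition at the concentration tested (going by the name of the read-out), a lower number less inhibition), compound 2 gives 63.7%, the highest of the two numbers measured. Compound 1 gives 52.4% in this assay, lower by a gap beyond the usual scatter. Compound 3 `O=S(=O)(c1ccc(-c2cnc(C3CC3)s2)cc1)N1CCc2ccccc21` is not yet measured. It differs from compound 2 by 2-cyclopropyl-1,3-thiazol-5-yl in place of 5-cyclopropyl-1,3,4-oxadiazol-2-yl on an aromatic carbon. Within the data shown here, no measured pair shows this exchange, so its effect is unknown here; a step of modest size, in either direction or none beyond the scatter, is expected as a number 3.7 percentage points lower from compound 2 to compound 3 (within the scatter). Compound 3 is expected to give about 60% in this assay, with a range from 38% to 80%.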

Compound 3, a percentage reported as inhibition, at one concentration (the size of the read-out at that concentration, not a potency): -10.1%
Compound 3: middle estimate off by 70.1 percentage points, on the high side; measured number below the stated range.
By their numbers in this assay, from the lowest: compound 3; then compound 1; then compound 2.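

On an aromatic carbon para to a large group, the choice of five-membered ring can decide the result: in this assay the exchange to 2-cyclopropyl-1,3-thiazol-5-yl brings a number 73.8 percentage points lower from compound 2 to compound 3 (beyond the scatter) even though both groups have 8 heavy atoms and a three-membered carbon ring. Nothing available here explains this drop. From the compounds shown here alone, it remains open whether the 5-cyclopropyl-1,3,4-oxadiazol-2-yl ring would keep its inhibition with an amine or a carboxylic acid in place of the cyclopropyl group. Going by these compounds, the contribution of the cyclopropyl group itself also remains open.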